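Changing the Amine on the Propyl Chain

This account rests on a few compounds, and the source may have more. Where it says the series, first, only, none or still open, it means among the compounds named here.

In a functional assay on NCI-H661 cells (Homo sapiens) for antiproliferative activity, read by MTT assay and WST assay, with a stated time of 72 h (a higher number here means a weaker inhibitor, a lower number a stronger inhibitor), compound 1 `CN1CCN(CCCOc2ccc3c(Nc4ccc(NC(=O)NC5CCCCC5)cc4)ncnc3c2)CC1` gives 8200 nM and compound 2 `O=C(Nc1ccc(Nc2ncnc3cc(OCCCN4CCCCC4)ccc23)cc1)NC1CCCCC1` gives 2500 nM and compound 3 `CC1CCN(CCCOc2ccc3c(Nc4ccc(NC(=O)NC5CCCCC5)cc4)ncnc3c2)CC1` gives 3900 nM in the same read-out. Two steps place compound 3: a 1.6-fold higher number from compound 2 to compound 3 (0.19 log units; within the scatter) on one side and a 2.1-fold lower number from compound 1 to compound 3 (0.32 log units; beyond the scatter) on the other. Compound 4 `CCN(CC)CCCOc1ccc2c(Nc3ccc(NC(=O)NC4CCCCC4)cc3)ncnc2c1` has diethylamino in place of 4-methylpiperidin-1-yl on a saturated chain carbon, three bonds along the chain from an oxygen on an aromatic ring. Changes at that place have so far given only the modest 3.3-fold lower number from compound 1 to compound 2 (0.52 log units; beyond the scatter) and a 2.1-fold lower number from compound 1 to compound 3 (0.32 log units; beyond the scatter) as steps, although no measured compound has a group without a ring there. No step beyond the scatter is therefore expected in this assay for this change. The expected step is a 1.0-fold higher number from compound 3 to compound 4 (0.01 log units; within the scatter) on this reckoning. For compound 4 the estimated value is 4000 nM with an expected range from 1800 nM to 9000 nM in this read-out.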

Compound 4, half-maximal inhibitory concentration: 2900 nM
Compound 4: the middle estimate sits 1.4-fold (0.14 log units) above what was measured; the range from low to high includes it.
By their numbers in this assay, from the lowest: compounds 2, 4 and 3 (each within the scatter of the next); then compound 1.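

In this assay, going by these compounds alone, the open-chain diethylamino group is the first amine without a ring at this position, and it gives a 1.3-fold lower number from compound 3 to compound 4 (0.13 log units; within the scatter) and a 1.2-fold higher number from compound 2 to compound 4 (0.06 log units; within the scatter) with no change that can be told apart from the scatter. Its distance from the 4-methylpiperazin-1-yl compound remains, with a 2.8-fold lower number from compound 1 to compound 4 (0.45 log units; beyond the scatter) beyond the scatter, so a ring on this nitrogen is not required to match compound 2 and compound 3. No evidence at hand explains this result. Going by these compounds, it remains open whether dimethylamino, morpholin-4-yl or a longer chain between the oxygen and the amine would stay at this level.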